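A Fluorine Step Repeated on a Second Core

The compounds below may be only part of what the source reports. "The series", "measured", "known", "first", "only" and "open" are said of these compounds alone.

Four closely related compounds are compared here. Compound 1, `O=C(c1ccccc1)N(/N=N/c1ccc([N+](=O)[O-])cc1Br)c1ccc([N+](=O)[O-])cc1Br`, is the parent of the first pair. In a functional assay on HeLa cells (Homo sapiens) for cytotoxicity, read by MTT assay, with a stated time of 72 h (on this read-out lower numbers stand for stronger inhibition and higher numbers for weaker inhibition), compound 1 gives 1530 nM. Compound 2, `O=C(c1ccccc1F)N(/N=N/c1ccc([N+](=O)[O-])cc1Br)c1ccc([N+](=O)[O-])cc1Br`, differs from it by one change, (fluoro in place of hydrogen on an aromatic carbon), and in this assay compound 2 gives 1200 nM. The step of a 1.3-fold lower number from compound 1 to compound 2 (0.11 log units; within the scatter) is therefore small enough to be indistinguishable from repeat measurement noise.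

Compound 3, `O=C(c1ccccc1)N(/N=N/c1ccc([N+](=O)[O-])cc1C(F)(F)F)c1ccc([N+](=O)[O-])cc1C(F)(F)F`, is built on a different core; the difference between the two cores is not broken down here. In this assay compound 3 gives 600 nM. Set against compound 1, that gap lies beyond the usual scatter; set against compound 2, it lies within it.

Compound 4, `O=C(c1ccccc1F)N(/N=N/c1ccc([N+](=O)[O-])cc1C(F)(F)F)c1ccc([N+](=O)[O-])cc1C(F)(F)F`, has not been measured. It stands to compound 3 exactly as compound 2 stands to compound 1: the change is fluoro in place of hydrogen on an aromatic carbon, the same change at the same kind of place, made on the second core instead of the first. Among the measured compounds shown here, the only precedent is the earlier step, and because that step a 1.3-fold lower number from compound 1 to compound 2 (0.11 log units; within the scatter) stayed within the scatter, the expected step here is a 1.2-fold lower number from compound 3 to compound 4 (0.08 log units; within the scatter). Compound 4 is expected to give about 500 nM in this assay, with a likely range from 250 nM to 1000 nM; a single precedent on a different core leaves that range fairly wide.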

Compound 4, half-maximal inhibitory concentration: 800 nM
Beside the measured number, compound 4's estimate is 1.6-fold (0.20 log units) below it, and the stated range covers the measured number.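

In this assay, putting fluoro in place of hydrogen, which turns phenyl into 2-fluorophenyl, gives a 1.3-fold higher number from compound 3 to compound 4 (0.12 log units; within the scatter), so on the second core this change again stays within the difference expected between repeat measurements. Set side by side, the steps on the two cores cannot be told apart: the same change on two cores in this assay, a 1.3-fold lower number (0.11 log units; within the scatter) from compound 1 to compound 2 and a 1.3-fold higher number (0.12 log units; within the scatter) from compound 3 to compound 4, 1.7-fold (0.23 log units) apart, within the scatter of two such steps. This shows that, across these two cores, the change carries over in a modest sense: neither step moves the read-out beyond the scatter, but that does not establish a real effect of fluoro on either core, and the opposite directions of the two small steps should not be read as a true difference between the cores.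

The compounds shown leave open whether a different group at this place on the benzoyl ring, such as chloro, methoxy, an amine or a carboxylic acid, would produce a step beyond the scatter. They also leave open whether the fluoro step would stay this small on a core carrying something other than the bromo or trifluoromethyl groups seen here, such as a nitrile or a methyl group.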